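Swapping an aryl ring on the shared core

The source may hold more compounds than are shown below. What is called first, only, known or untested is meant among the compounds shown, and "the series" means these compounds.

Of the compounds shown here, two built on the same core have been measured in a functional assay on SGC-7901 cells (Homo sapiens) for cytotoxicity, read by MTT assay, with a stated time of 48 h; on this read-out higher numbers stand for weaker inhibition and lower numbers for stronger inhibition. Compound 1 `Cc1ncc([N+](=O)[O-])n1CCSc1nnc(-c2ccc([N+](=O)[O-])cc2)o1` carries a 4-nitrophenyl group and in this assay compound 1 gives 12200 nM. Among the measured compounds shown here, compound 2 `Cc1ncc([N+](=O)[O-])n1CCSc1nnc(-c2ccc(F)cc2)o1` is its counterpart with fluoro in place of nitro on an aromatic carbon, and in this assay compound 2 gives 5300 nM, which is the lowest of the two numbers so far; the step of a 2.3-fold lower number from compound 1 to compound 2 (0.36 log units; beyond the scatter) is a modest one.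

Compound 3 `Cc1ncc([N+](=O)[O-])n1CCSc1nnc(-c2ccnc(Cl)c2)o1` differs from compound 2 in one place: 2-chloropyridin-4-yl in place of 4-fluorophenyl on an aromatic carbon. For the measured compounds named here, the only measured step, a 2.3-fold lower number from compound 1 to compound 2 (0.36 log units; beyond the scatter), concerns a different exchange, so nothing measured bears directly on this change, and no strong shift in either direction is expected. The step from compound 2 to compound 3 is estimated as a 1.1-fold higher number from compound 2 to compound 3 (0.05 log units; within the scatter), within the scatter. For compound 3 the expected value in this assay is 6000 nM, with a range from 2500 nM to 15000 nM.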

Compound 3, half-maximal inhibitory concentration: 32300 nM
Estimate against measurement, compound 3: 5.4-fold (0.73 log units) below; the measured number lies above the stated range.
By their numbers in this assay, from the lowest: compound 2; then compound 1; then compound 3.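

In this assay, the aryl position on the shared core proves sensitive to more than the exchange of one substituent on a phenyl ring: 2-chloropyridin-4-yl in place of 4-fluorophenyl gives a 6.1-fold higher number from compound 2 to compound 3 (0.78 log units; beyond the scatter) and so weakens inhibition, whereas the earlier exchange gave a 2.3-fold lower number from compound 1 to compound 2 (0.36 log units; beyond the scatter) and ran the other way. By the printed values, compound 3 also has a higher number than compound 1, so among these three compounds the entering group gives the weakest reading, and the position tolerates neither aryl group equally. The change swaps the ring fluorine for a chlorine and adds a ring nitrogen with its hydrogen-bond acceptor in one step, and nothing available here accounts for the loss.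

The compounds shown do not separate the part played by the ring nitrogen from that of the chlorine. Going by these compounds, how a chlorophenyl group, an unsubstituted pyridyl ring or an amine on the aryl ring would read in this assay remains open.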